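A few compounds are considered here, and "the series" means these few. Any claim that something is new, unique, unknown or untested is made for them only; others in the source may bear on it.

Within the data shown here, in a functional assay on RD cells (Homo sapiens) for inhibition, read by luminescence and ATP content, with a stated time of 72 h (on this read-out higher numbers stand for lower toxicity in this test and lower numbers for higher toxicity in this test), none of the three compounds measured so far reaches a number; each stops at a limit of the test. Compound 1, `CCOC(=O)c1cnc2ccc(-c3cccc(N)c3)cc2c1`, gives > 7400 nM, which is a limit. Compound 2, `Nc1ccc(-c2ccc3ncc(-c4noc(C(F)(F)F)n4)cc3c2)cn1`, gives > 2500 nM, also a limit. Compound 3, `CCc1nc(-c2cnc3ccc(-c4cccc(N)c4)cc3c2)no1`, gives > 7400 nM, again a limit. Among the measured compounds shown here, the single step among them, a step that the two limits leave unreadable from compound 1 to compound 3, therefore has no readable size. What stands behind the three values is only the limit of > 2500 nM in this assay, at which 1 of the 3 values shown sits, and (the limit of > 7400 nM in this assay, at which 2 of the 3 values shown sit).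

Compound 4, `CCc1nc(-c2cnc3ccc(-c4ccc(OC)cc4)cc3c2)no1`, has not yet been measured in this assay. It differs from compound 3 in one place: 4-methoxyphenyl in place of 3-aminophenyl on an aromatic carbon. For the measured compounds named here, no measured step touches this part of the structure, so nothing among the data shows how far such a change moves the read-out. What the three measured compounds share is that none produced a number. Compound 4 is therefore expected to sit where compound 3 sits, most likely again at a limit. The step is estimated as a step that the limit leaves unreadable from compound 3 to compound 4. For compound 4 the expected value is 10000 nM, with a range from 3000 nM to 40000 nM.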

Compound 4, half-maximal cytotoxic concentration: > 2500 nM
Compound 4 gave a limit, no number (the forecaster's own chance of this, stated with the estimate: 80%); the middle value does not contradict the limit.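

Compound 3 and compound 4 each stop at a limit of the test, so the step between them cannot be read. The compounds shown leave open how far 4-methoxyphenyl in place of 3-aminophenyl moves the read-out, and at what concentration any of them becomes toxic.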